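A few compounds are considered here, and "the series" means these few. Any claim that something is new, unique, unknown or untested is made for them only; others in the source may bear on it.

Measured in an assay on T-REx-293 cells for inhibition of potassium channel subfamily T member 1 (Homo sapiens), read by patch clamp; a lower number here means a stronger inhibitor, a higher number a weaker inhibitor:
compound 1, `Cc1cccc(-c2noc([C@H](C)NC(=O)c3cc(C4CC4)nn3C)n2)c1`, gives 167 nM
compound 2, `C[C@H](NS(=O)(=O)c1cc(C(F)(F)F)nn1C)c1nc(-c2cccc(F)c2)no1`, gives > 30000 nM
compound 3, `Cc1cc(-c2noc([C@H](C)NC(=O)c3cc(C(F)(F)F)nn3C)n2)ccn1`, gives 165 nM

The entry of compound 2 is a limit of the assay rather than a number, and it is the only such entry, as the limit of > 30000 nM in this assay, at which 1 of the 3 values shown sits, shows. Of the two numbers, compound 3 and compound 1 sit within the usual scatter of each other, so neither can be called the stronger inhibitor on these data. Compound 3 carries a methyl group on its six-membered aromatic ring and a trifluoromethyl group on the other side of the shared core.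

The next compound, compound 4, `C[C@H](NC(=O)c1cc(C(F)(F)F)nn1C)c1nc(-c2ccnc(N(C)C)c2)no1`, is compound 3 with one change: dimethylamino in place of methyl on an aromatic carbon. Within the data shown here, no pair of measured compounds differs in only this place, so no measured step shows what this change does. The expectation is a step from compound 3 to compound 4 in this assay that stays within the scatter or is small, with no clear direction, meaning a 1.2-fold higher number from compound 3 to compound 4 (0.08 log units; within the scatter). Compound 4 is therefore estimated at 200 nM, with a range from 60 nM to 700 nM.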

Compound 4, half-maximal inhibitory concentration: 454 nM
For compound 4 the middle estimate is 2.3-fold (0.36 log units) below the measured one, and the stated range covers the measured number.
By their numbers in this assay, from the lowest: compounds 3 and 1 (each within the scatter of the next); then compound 4. At a limit, above all of these: compound 2.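

In this assay, putting dimethylamino in place of methyl next to the ring nitrogen gives a 2.8-fold higher number from compound 3 to compound 4 (0.44 log units; beyond the scatter) and so a modest loss of strength that lies beyond the scatter. Among these compounds, this is the first measured change at this position, and it shows that the position responds to what sits there, yet the larger group costs only a modest step and compound 4 remains a measurable inhibitor. Nothing measured here bears on why the number rises.

From the compounds shown here alone, whether any group at this place can beat methyl stays open, and so does the question of which part of dimethylamino carries the loss. A plain amine or a methoxy group on the same carbon would help to separate the effect of the nitrogen from that of its two methyl groups.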